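The source may report more compounds than this note shows. Statements on the series, on what has been measured and on what is new or still open speak of the compounds shown alone.

Measured so far:
Compound 1 `O=C(Nc1cc(C(F)(F)F)cc(C(F)(F)F)c1)c1cnc(Cl)nc1` gives 300 nM in an assay on Jurkat cells for activation of nuclear factor NF-kappa-B complex (Homo sapiens); a lower number here means a stronger inhibitor, a higher number a weaker inhibitor.
Compound 2 `CCCc1nc(Cl)ncc1C(=O)Nc1cc(C(F)(F)F)cc(C(F)(F)F)c1` gives 500 nM in this assay.

Among the measured compounds shown here, compound 1 has the lowest of the two numbers seen so far, but only the step of a 1.7-fold higher number from compound 1 to compound 2 (0.22 log units; within the scatter) separates it from compound 2, so the two cannot be told apart. Compound 3 `O=C(Nc1cc(C(F)(F)F)cc(C(F)(F)F)c1)c1cc(Cl)nc(Cl)n1` is the unmeasured compound. It differs from compound 1 in one place: 2,6-dichloropyrimidin-4-yl in place of 2-chloropyrimidin-5-yl on a carbonyl carbon. For the measured compounds named here, the only measured step, from compound 1 to compound 2, concerns a propyl group on an aromatic carbon and leaves the part of the molecule that changes here untouched, so it gives no direct guide. Moving the point where the ring carries the carbonyl and adding a second chlorine is a larger change than anything measured, and the direction is open. A modest weakening is expected, with wide uncertainty: the step of a 2.7-fold higher number from compound 1 to compound 3 (0.43 log units; beyond the scatter) is estimated. Compound 3 is therefore expected to give 800 nM, within 200 nM to 4000 nM.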

Compound 3, half-maximal inhibitory concentration: > 10000 nM
Compound 3 was reported as a limit (the forecaster's own chance of this, stated with the estimate: 10%); middle value at least 12-fold (1.09 log units) away from the limit.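

Replacing 2-chloropyrimidin-5-yl with 2,6-dichloropyrimidin-4-yl on the carbonyl carbon gives an at least 33-fold higher number from compound 1 to compound 3 (1.52 log units; beyond the scatter), whereas the propyl change gave a 1.7-fold higher number from compound 1 to compound 2 (0.22 log units; within the scatter). Among the compounds shown here, this is the first sign that the group on the carbonyl carbon is not free to vary in this assay: a swap of one chlorine-bearing ring for another of the same kind, differing only in its attachment point and its chlorine count, is enough to produce a large step. The number for compound 3 is a limit of the assay and not a measured value, so the true size of the step is not known: the limit of > 10000 nM in this assay, at which 1 of the 3 values shown sits.

This step combines a second chlorine with a different attachment point, and the compounds shown do not separate the two. They also leave open how an amine or a methoxy group would fare in place of the chlorine of 2-chloropyrimidin-5-yl.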